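A few compounds are considered here, and "the series" means these few. Any claim that something is new, unique, unknown or untested is made for them only; others in the source may bear on it.

Going by the values given here, compound 1 `COc1ccnc(Nc2cc3[nH]c(-c4cccc(C(F)(F)F)c4)nc3cn2)c1` is tested in an ADME assay on microsomes from liver (Rattus norvegicus) for metabolic stability, read by LC-MS, with a stated time of 30 min, tested at 0.1 uM (on this read-out higher numbers stand for a more stable compound and lower numbers for a less stable compound), where compound 1 gives 71%, the highest of the three numbers known here. Compound 2 `Fc1ccc(-c2nc3cnc(Nc4ccccn4)cc3[nH]2)cc1C(F)(F)F` gives 67%, and compound 3 `Fc1ccc(Nc2cc3[nH]c(-c4cccc(C(F)(F)F)c4)nc3cn2)nc1` gives 42%. Against compound 3 the data show a number 29 percentage points lower from compound 1 to compound 3 (beyond the scatter), while the numbers of compound 1 and compound 2 lie within the scatter of each other. Compound 4 `FC(F)(F)c1ccc(Nc2cc3[nH]c(-c4cccc(C(F)(F)F)c4)nc3cn2)nc1` differs from compound 1 in one place: 5-(trifluoromethyl)pyridin-2-yl in place of 4-methoxypyridin-2-yl on a nitrogen on an aromatic ring. Among the compounds with values here, the only measured step that bears on this is the one from compound 1 to compound 3, which also replaced the 4-methoxypyridin-2-yl group and lowered the number by a modest amount. A comparable drop is therefore expected, a number 26 percentage points lower from compound 1 to compound 4 (beyond the scatter). Compound 4 is estimated at 45%, between 25% and 65%.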

Compound 4, percent of the compound remaining: 89%
The estimate for compound 4 lay 44 percentage points below the measured number; the measured number lies above the stated range.
By their numbers in this assay, from the lowest: compound 3; then compounds 2 and 1 (each within the scatter of the next); then compound 4.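

In this assay, going by these compounds alone, the 5-(trifluoromethyl)pyridin-2-yl group gives a number 18 percentage points higher from compound 1 to compound 4 (beyond the scatter), so replacing 4-methoxypyridin-2-yl on this nitrogen need not lower the number, as the one earlier step did. Trifluoromethyl in place of fluoro on an aromatic carbon gives a number 47 percentage points higher from compound 3 to compound 4 (beyond the scatter), showing that the outcome depends strongly on which group the pyridine ring carries. Nothing available explains this difference. On these data alone, it remains open how a nitrile or an amine in place of the trifluoromethyl would compare.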